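Compound 2 and a naphthalenyl swap on its sulfonate oxygen

The source may report more compounds than this note shows. Statements on the series, on what has been measured and on what is new or still open speak of the compounds shown alone.

Compound 1 (`CCc1ccccc1OS(=O)(=O)C1CC2OC1C(c1ccc(/C=C/c3cc(OC)cc(OC)c3)cc1)=C2c1ccc(O)cc1`) gives 49800 nM
Compound 2 (`O=S(=O)(Oc1ccccc1C(F)(F)F)C1CC2OC1C(c1ccc(/C=C/c3cc(O)cc(O)c3)cc1)=C2c1ccc(O)cc1`) gives 18300 nM

In a functional assay on MCF7 cells (Homo sapiens) for antiproliferative activity, read by MTT assay, with a stated time of 72 h (on this read-out lower numbers stand for stronger inhibition and higher numbers for weaker inhibition), compound 2 holds the lower of the two numbers (18300 nM), while compound 1 (49800 nM) lies above it by more than the usual scatter. These two compounds differ in more than one place, so their gap cannot be assigned to any single change.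

Compound 3 (`O=S(=O)(Oc1cccc2ccccc12)C1CC2OC1C(c1ccc(/C=C/c3cc(O)cc(O)c3)cc1)=C2c1ccc(O)cc1`) departs from compound 2 in one place only, with naphthalen-1-yl in place of 2-(trifluoromethyl)phenyl on an oxygen. Within the data shown here, no measured pair here isolates this change, so the data give no direct guide to its size. The expectation therefore rests on compound 2 (18300 nM) as the closest reference, and no step beyond the scatter is expected in this assay in either direction. The estimated step is a 1.1-fold lower number from compound 2 to compound 3 (0.06 log units; within the scatter) and is expected to remain small. For compound 3 the expected value is 16000 nM (estimated range 6000 nM to 42000 nM).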

Compound 3, half-maximal inhibitory concentration: 11000 nM
Compound 3: middle estimate off by 1.5-fold (0.16 log units), on the high side; the measured number falls inside the stated range.
By their numbers in this assay, from the lowest: compounds 3 and 2 (each within the scatter of the next); then compound 1.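

In this assay, among these compounds, the change from 2-(trifluoromethyl)phenyl to naphthalen-1-yl, on an oxygen whose other neighbour is the sulfonyl sulfur, gives the first step that can be read between two compounds differing in one place: a 1.7-fold lower number from compound 2 to compound 3 (0.22 log units; within the scatter). The two groups have the same count of heavy atoms, but one brings a single six-membered aromatic ring with three fluorine atoms and the other two six-membered aromatic rings of carbon only, and this exchange leaves the read-out within the usual scatter. Nothing among the available observations explains why the exchange leaves the number within the scatter.

The compounds shown have only aromatic groups on this oxygen, so it remains open whether a group of another kind, such as a simple butyl chain or a ring carrying a carboxylic acid or an amine, would give a similar number. The gap between compound 1 and the other two also stays unassigned, since compound 1 differs from them in more than one place.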